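The source may report more compounds than this note shows. Statements on the series, on what has been measured and on what is new or still open speak of the compounds shown alone.

Of the compounds shown here, two of this set have been measured in an assay (Rattus norvegicus) for inhibition of Fatty-acid amide hydrolase 1 (Homo sapiens); a lower number here means a stronger inhibitor, a higher number a weaker inhibitor. Compound 1, with the structure `NC(=O)c1ccc(-c2cnc(C(=O)CCCCCCc3ccccc3)o2)nc1`, gives 1.2 nM. Compound 2, with the structure `OC(CCCCCCc1ccccc1)c1ncc(C(F)(F)F)o1`, gives 2300 nM, which is the higher of the two numbers, and the gap between compound 2 and compound 1 is well beyond the scatter. The next compound, compound 3, has the structure `NC(=O)c1ccc(-c2cnc(C(O)CCCCCCc3ccccc3)o2)nc1`. It differs from compound 2 by 5-carbamoylpyridin-2-yl in place of trifluoromethyl on an aromatic carbon. Among the measured compounds shown here, no step between two measured compounds isolates this exchange, so the size of its effect is not known from the measured pair. Compound 3 is nonetheless expected to move toward a lower number, with an estimated step of a 12-fold lower number from compound 2 to compound 3 (1.06 log units; beyond the scatter) in this assay. On that basis compound 3 is estimated at 200 nM, with a range from 40 nM to 1000 nM.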

Compound 3, inhibition constant: 3000 nM
Compound 3: the middle estimate sits 15-fold (1.18 log units) below what was measured, and the stated range ends below it.
By their numbers in this assay, from the lowest: compound 1; then compounds 2 and 3 (each within the scatter of the next).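

In this assay, the exchange on this aromatic carbon, next to the ring oxygen, gives a 1.3-fold higher number from compound 2 to compound 3 (0.12 log units; within the scatter), so with the alcohol carbon kept in the chain, trifluoromethyl and 5-carbamoylpyridin-2-yl are not told apart at this position. Compound 3 gives 3000 nM, while compound 1, which carries the same 5-carbamoylpyridin-2-yl with a carbonyl in place of the alcohol carbon, gives 1.2 nM, so this group alone does not bring the low number seen with compound 1. Nothing available here accounts for the absence of a change in this exchange.

On these data alone, what remains open is whether trifluoromethyl and 5-carbamoylpyridin-2-yl would also match when the chain bears a carbonyl. As far as these compounds go, how a carboxylic acid or an amine would fare at this position also remains open.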